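A few compounds are considered here, and "the series" means these few. Any claim that something is new, unique, unknown or untested is made for them only; others in the source may bear on it.

Measured so far:
Compound 2 `O=C(CCl)Nc1ccc(S(=O)(=O)Oc2ccccc2I)cc1` — 2500 nM
Compound 1 `CCCCCC(=O)Nc1ccc(S(=O)(=O)Oc2ccccc2I)cc1` — 10000 nM

Within the data shown here, in a functional assay on MCF7 cells (Homo sapiens) for antiproliferative activity, read by sulforhodamine B assay, with a stated time of 48 h (a higher number here means a weaker inhibitor, a lower number a stronger inhibitor), compound 2 gives the lowest of the two numbers measured; its nearest neighbour is compound 1, from which the single step of a 4.0-fold lower number from compound 1 to compound 2 (0.60 log units; beyond the scatter) separates it. Among the measured compounds shown here, that step is the only one measured and it exchanges the substituent on the saturated chain carbon bound to the carbonyl carbon, so it bears directly on the step ahead.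

Compound 3 `O=C(CCCCl)Nc1ccc(S(=O)(=O)Oc2ccccc2I)cc1` differs from compound 2 by 2-chloroethyl in place of chloro on a saturated chain carbon bound to a carbonyl carbon. The chain of compound 3 grows back toward the length seen in compound 1 while the chlorine remains, so the expected step of a 2.0-fold higher number from compound 2 to compound 3 (0.30 log units; within the scatter) points back toward compound 1, though not all the way, because the step of a 4.0-fold lower number from compound 1 to compound 2 (0.60 log units; beyond the scatter) linked chain and chlorine together and cannot be split further. The estimate for compound 3 in this assay is therefore 5000 nM, with a range from 1500 nM to 20000 nM.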

Compound 3, half-maximal inhibitory concentration: 6300 nM
The estimate for compound 3 lay 1.3-fold (0.10 log units) below the measured number, within the range that was stated.
By their numbers in this assay, from the lowest: compound 2; then compounds 3 and 1 (each within the scatter of the next).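

In this assay, extending chloromethyl to 3-chloropropyl while keeping the chlorine gives a 2.5-fold higher number from compound 2 to compound 3 (0.40 log units; beyond the scatter), so within this pair the short chloro-bearing chain has the lower number. With the chain length held, the chlorine on the far chain carbon gives a 1.6-fold lower number from compound 1 to compound 3 (0.20 log units; within the scatter), which leaves compound 3 and compound 1 indistinguishable, and across these three compounds only the chlorine on the carbon bound to the carbonyl carbon, in compound 2, stands apart. The data at hand offer no independent measurement that accounts for this difference.

Still open, on these data alone, is whether the lower number of compound 2 belongs to the chlorine or to the short chain alone. A plain methyl or a bromomethyl at the same place would help separate these two readings.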